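Swapping the dimethylamino group of compound 2

The compounds below may be only part of what the source reports. "The series", "measured", "known", "first", "only" and "open" are said of these compounds alone.

In a functional assay on HepG2 cells (Homo sapiens) for antiproliferative activity, read by MTT assay, with a stated time of 72 h (on this read-out higher numbers stand for weaker inhibition and lower numbers for stronger inhibition), compound 1 `O=C(N/N=C/c1cc(Br)c(O)c(Br)c1)Nc1ccc(Oc2ccnc3[nH]ccc23)c(F)c1` gives 6520 nM and compound 2 `CN(C)CCn1cccc1/C=N/NC(=O)Nc1ccc(Oc2ccnc3[nH]ccc23)c(F)c1` gives 8980 nM. Compound 3 `CN(C)CCn1cccc1/C=N/NC(=O)Nc1ccc(Oc2ccnc3[nH]ccc23)cc1` is recorded as "not active" (no number reported), so it offers no number to set beside the other two. Within the data shown here, compound 2 therefore stands level with compound 1, as the only measured step, a 1.4-fold higher number from compound 1 to compound 2 (0.14 log units; within the scatter), lies within the scatter.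

Compound 4 `O=C(N/N=C/c1cccn1CCCN1CCCCC1)Nc1ccc(Oc2ccnc3[nH]ccc23)c(F)c1` differs from compound 2 in one place: (piperidin-1-yl)methyl in place of dimethylamino on a saturated chain carbon, two bonds along the chain from an aromatic nitrogen. In words, (piperidin-1-yl)methyl takes the place of dimethylamino on a saturated chain carbon, two bonds along the chain from an aromatic nitrogen. Read one bond further out, 2-(dimethylamino)ethyl becomes 3-(piperidin-1-yl)propyl.

No measurement tests this exchange directly. The closest evidence is a 1.4-fold higher number from compound 1 to compound 2 (0.14 log units; within the scatter), a change of a whole group that stayed within the scatter, so no step beyond the scatter is expected in this assay. The estimated step is a 1.1-fold lower number from compound 2 to compound 4 (0.05 log units; within the scatter). For compound 4 the expected value is 8000 nM, with an estimated range from 3000 nM to 20000 nM.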

Compound 4, half-maximal inhibitory concentration: 2840 nM
Beside the measured number, compound 4's estimate is 2.8-fold (0.45 log units) above it, outside the stated range (below it).
By their numbers in this assay, from the lowest: compound 4; then compounds 1 and 2 (each within the scatter of the next).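

In this assay, this exchange gives the first step beyond the scatter among the compounds shown: a 3.2-fold lower number from compound 2 to compound 4 (0.50 log units; beyond the scatter), a modest change. The end of the saturated chain on the aromatic nitrogen therefore affects the read-out, something the earlier step from the dibromohydroxyphenyl group to the pyrrole group, which stayed within the scatter, could not reveal. No measurement available here accounts for the lower number.

The piperidine ring and the longer chain enter together, so the compounds shown leave open which of the two carries the step. A 2-(piperidin-1-yl)ethyl group or a 3-(dimethylamino)propyl group in the same place would separate them, and a 3-(morpholin-4-yl)propyl group would show whether a second hetero atom in the ring is tolerated.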